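A few compounds are considered here, and "the series" means these few. Any claim that something is new, unique, unknown or untested is made for them only; others in the source may bear on it.

Compound 1 `O=C1[C@H]2N=NN(Cc3nc(-c4ccccc4)no3)[C@H]2C(=O)N1c1ccccc1`: 47.3 ug/mL
Compound 2 `CSc1ccc(-c2noc(CN3N=N[C@@H]4C(=O)N(c5ccccc5)C(=O)[C@@H]43)n2)cc1`: > 100 ug/mL
Compound 3 `O=C1[C@H]2N=NN(Cc3nc(-c4ccc(Br)cc4)no3)[C@H]2C(=O)N1c1ccccc1`: 58.6 ug/mL

In an ADME assay on L6 cells (Rattus norvegicus) for cytotoxicity, read by resazurin assay, with a stated time of 72 h (on this read-out lower numbers stand for stronger inhibition and higher numbers for weaker inhibition), compound 3 sits within the scatter of compound 1, as a 1.2-fold higher number from compound 1 to compound 3 (0.09 log units; within the scatter) shows. The entry for compound 2 is a limit of the assay, not a number. Compound 4 `COc1ccc(-c2noc(CN3N=N[C@@H]4C(=O)N(c5ccccc5)C(=O)[C@@H]43)n2)cc1` carries methoxy in place of bromo on an aromatic carbon. Within the data shown here, three measured steps bear on this carbon: a 1.2-fold higher number from compound 1 to compound 3 (0.09 log units; within the scatter), an at least 2.1-fold higher number from compound 1 to compound 2 (0.32 log units; beyond the scatter) and an at least 1.7-fold lower number from compound 2 to compound 3 (0.23 log units; that floor lies within the scatter). None of them involves methoxy, so the expected change in this assay is a small rise that may not clear the scatter, namely a 1.2-fold higher number from compound 3 to compound 4 (0.08 log units; within the scatter). The estimate for compound 4 is 70 ug/mL, with an expected range from 35 ug/mL to 130 ug/mL.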

Compound 4, half-maximal inhibitory concentration: > 100 ug/mL
Compound 4: only a limit was reported; the forecaster's own chance of this, stated with the estimate: 35%; middle value at least 1.4-fold (0.15 log units) from the limit.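

Methoxy in place of hydrogen gives an at least 2.1-fold higher number from compound 1 to compound 4 (0.32 log units; beyond the scatter), so on this carbon methoxy, like methylsulfanyl, moves the number beyond the scatter, while bromo stays within it. Methoxy in place of bromo gives an at least 1.7-fold higher number from compound 3 to compound 4 (0.23 log units; that floor lies within the scatter), a floor that does not by itself separate the two groups. The step between compound 2 and compound 4 cannot be read, since both entries are limits: the limit of > 100 ug/mL in this assay, at which 2 of the 4 values shown sit.

Going by these compounds, how far past that limit either compound lies remains open. So does whether an amine or a carboxylic acid on this carbon would also give a limit.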